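The compounds below may be only part of what the source reports. "The series", "measured", "known", "first", "only" and "open" are said of these compounds alone.

Compound 2 `COc1ccc(Cc2nnc(CN(c3cccc(Cl)c3C)S(=O)(=O)c3ccc(C)cc3)o2)cc1` gives 6.31 nM in an assay on CHO cells for displacement of a labelled ligand from prostaglandin E2 receptor EP1 subtype (Homo sapiens) (on this read-out higher numbers stand for weaker inhibition and lower numbers for stronger inhibition), the lowest of the two numbers available, with compound 3 `COc1ccc(Cc2nnc(CN(c3cccc(Cl)c3Cl)S(=O)(=O)c3ccc(C)cc3)o2)cc1` at 7.94 nM close behind; compound 1 `CCc1ccccc1N(Cc1nnc(Cc2ccc(OC)cc2)o1)S(=O)(=O)c1ccc(C)cc1`, which differs in several places, gives 126 nM; 126 nM (2 entries). Going by the values given here, the only single-point step, a 1.3-fold higher number from compound 2 to compound 3 (0.10 log units; within the scatter), touches a different part of the molecule. Compound 4 `Cc1ccc(S(=O)(=O)N(Cc2nnc(Cc3ccc(C(F)(F)F)cc3)o2)c2cccc(Cl)c2C)cc1` differs from compound 2 by trifluoromethyl in place of methoxy on an aromatic carbon. Among the compounds with values here, no measured pair shows this change, so the direction rests on no direct evidence; the expectation is a modest weakening, with a wide range. For compound 4 the estimate in this assay is 15 nM, between 4 nM and 60 nM, corresponding to an expected step of a 2.4-fold higher number from compound 2 to compound 4 (0.38 log units; beyond the scatter).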

Compound 4, half-maximal inhibitory concentration: 50.1 nM
Compound 4: middle estimate off by 3.3-fold (0.52 log units), on the low side, within the range that was stated.
By their numbers in this assay, from the lowest: compounds 2 and 3 (each within the scatter of the next); then compound 4.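

The 4-methoxybenzyl end of the molecule is sensitive to change: in this assay, replacing methoxy with trifluoromethyl gives a 7.9-fold higher number from compound 2 to compound 4 (0.90 log units; beyond the scatter) and so weakens inhibition. This is the first step shown at this end of the molecule, as the earlier pair differs elsewhere. Nothing measured here explains the loss. One swap cannot separate the effect of removing methoxy from that of adding trifluoromethyl. As far as these compounds go, whether an ethoxy group, a hydroxyl group or an amine at this place would match compound 2 remains open.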